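Swapping the sulfonyl aryl: 2-bromophenyl replaces 3-methylphenyl

This account rests on a few compounds, and the source may have more. Where it says the series, first, only, none or still open, it means among the compounds named here.

Three compounds share one core and differ only in the aryl group on the sulfonyl sulfur. In a functional assay on DLD-1 cells (Homo sapiens) for antiproliferative activity, read by CellTiter-Glo, with a stated time of 72 h (on this read-out higher numbers stand for weaker inhibition and lower numbers for stronger inhibition), compound 1 `CC1CCN(C2CCN(S(=O)(=O)c3cccc(-c4ccccc4F)c3)CC2)CC1` gives 10 nM, compound 2 `CC1CCN(C2CCN(S(=O)(=O)c3cccc(-c4ccc(Cl)cc4)c3)CC2)CC1` gives 15 nM and compound 3 `Cc1cccc(S(=O)(=O)N2CCC(N3CCC(C)CC3)CC2)c1` gives 25 nM. Compound 3 has the highest number of the three, a 2.5-fold higher number from compound 1 to compound 3 (0.40 log units; beyond the scatter) while a 1.7-fold higher number from compound 2 to compound 3 (0.22 log units; within the scatter). Compound 4 `CC1CCN(C2CCN(S(=O)(=O)c3ccccc3Br)CC2)CC1` brings (2-bromophenyl in place of 3-methylphenyl on a sulfonyl sulfur). Among the measured compounds shown here, no measured step places a halogen directly on this ring; the steps from compound 1 and compound 2 to compound 3 only show that changing this aryl group shifts this assay by a modest amount at most. Compound 4 is therefore expected to stay near compound 3, with a 1.2-fold higher number from compound 3 to compound 4 (0.08 log units; within the scatter), and the estimate for compound 4 in this assay is 30 nM, ranging from 10 nM to 90 nM.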

Compound 4, half-maximal inhibitory concentration: 3 nM
Compound 4: the middle estimate sits 10-fold (1.00 log units) above what was measured; the whole stated range lies above it.
By their numbers in this assay, from the lowest: compound 4; then compounds 1, 2 and 3 (each within the scatter of the next, the first and the last beyond it).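

In this assay the aryl group on the sulfonyl sulfur moves the number further than any earlier step did: an 8.3-fold lower number from compound 3 to compound 4 (0.92 log units; beyond the scatter). The 3-methylphenyl and 2-bromophenyl groups have the same heavy-atom count and one aromatic ring each, so those counts do not separate them. Nothing measured here accounts for the shift. The compounds shown leave open whether the bromine itself or its place on the ring carries this step. A 3-bromophenyl or 2-methylphenyl group on the sulfonyl sulfur would separate the two.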